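Swapping a Chloropropyl Alkyne Tail for Tert-Butyl

The compounds below may be only part of what the source reports. "The series", "measured", "known", "first", "only" and "open" are said of these compounds alone.

Compound 1 `CC(=O)OCC(CCn1cc(C#CCCCCl)c(=O)n(C(=O)c2ccccc2)c1=O)COC(C)=O` carries a 5-chloropent-1-yn-1-yl chain on its core. In a functional assay on SW-620 cells (Homo sapiens) for antiproliferative activity, read by MTT assay, with a stated time of 72 h (on this read-out higher numbers stand for weaker inhibition and lower numbers for stronger inhibition), compound 1 reaches only a limit of the assay, > 100000 nM. Compound 2 `CC(=O)OCC(CCn1cc(C#CC(C)(C)C)c(=O)n(C(=O)c2ccccc2)c1=O)COC(C)=O` differs from compound 1 in one place: tert-butyl in place of 3-chloropropyl on a triple-bonded carbon. In this assay compound 2 likewise gives only a limit, > 100000 nM. The step that the two limits leave unreadable from compound 1 to compound 2 cannot be sized because the limit of > 100000 nM in this assay, at which 3 of the 3 values shown sit, holds for both of its ends.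

Compound 3 `O=c1[nH]c(=O)n(CCC(CO)CO)cc1C#CCCCCl` carries the same 5-chloropent-1-yn-1-yl chain on another core; the difference between the two cores is not broken down here. In this assay compound 3 also gives only a limit, > 100000 nM.

Compound 4 `CC(C)(C)C#Cc1cn(CCC(CO)CO)c(=O)[nH]c1=O` has not yet been measured. It differs from compound 3 by the same change that separates compound 1 from compound 2: tert-butyl in place of 3-chloropropyl on a triple-bonded carbon. On the core of compound 1 this change left the read-out at the limit, and nothing among the three measured compounds points to a numerical value on either core, since the limit of > 100000 nM in this assay, at which 3 of the 3 values shown sit, applies to every one of them.

For compound 4 in this assay the expectation is therefore a value that again ends at the limit, estimated at 200000 nM. Going by the values given here, the step this estimate means, a step that the limit leaves unreadable from compound 3 to compound 4, is expected to be as unreadable as the one between compound 1 and compound 2, because the limit of > 100000 nM in this assay, at which 3 of the 3 values shown sit, is all the evidence available for the change. Only an actual measurement of compound 4 can say whether the second core behaves differently.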

Compound 4, half-maximal inhibitory concentration: > 100000 nM
Compound 4: no number, only a limit; the forecaster's own chance of this, stated with the estimate: 90%; the middle value lies beyond the limit too.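

In this assay compound 4 gives > 100000 nM, which is a limit and not a number. The step from compound 3 to compound 4 therefore has no readable size, since neither compound has a number: the limit of > 100000 nM in this assay, at which 4 of the 4 values shown sit.

The compounds shown leave open whether swapping 3-chloropropyl for tert-butyl changes the read-out on either core, and what the true value of any of these four compounds is.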